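From Phenyl to 3-Phenylprop-2-en-1-yl on a Ring Nitrogen

A few compounds are considered here, and "the series" means these few. Any claim that something is new, unique, unknown or untested is made for them only; others in the source may bear on it.

In a functional assay on HL-60 cells (Homo sapiens) for cytotoxicity, read by MTT assay, with a stated time of 24 h (a lower number here means a stronger inhibitor, a higher number a weaker inhibitor), compound 1 `BrCCCOc1c(Br)cc(Br)cc1Oc1ccc(Br)cc1Br` gives 29.9 ug/mL and compound 2 `Brc1ccc(Oc2cc(Br)cc(Br)c2OCCCCCN2CCN(c3ccccc3)CC2)c(Br)c1` gives 41.6 ug/mL. These two values lie within the usual scatter of each other, so compound 2 stands level with compound 1 on the numbers available.

Compound 3 `Brc1ccc(Oc2cc(Br)cc(Br)c2OCCCCCN2CCN(C/C=C/c3ccccc3)CC2)c(Br)c1` has not yet been measured. It differs from compound 2 in one place: 3-phenylprop-2-en-1-yl in place of phenyl on an amine nitrogen in a ring. In words, 3-phenylprop-2-en-1-yl stands in place of phenyl on an amine nitrogen in a ring.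

Going by the values given here, no two measured compounds differ in only one place, so the data give no direct guide to this change. Compound 1 at 29.9 ug/mL and compound 2 at 41.6 ug/mL lie close together although they carry different groups on the shared core, and this gives some reason to expect little movement here. The expected step in this assay is small, toward a lower number and not beyond the scatter: a 1.4-fold lower number from compound 2 to compound 3 (0.14 log units; within the scatter). The estimate for compound 3 is 30 ug/mL, with the measurement expected to fall between 12 ug/mL and 60 ug/mL.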

Compound 3, half-maximal inhibitory concentration: 47.2 ug/mL
Beside the measured number, compound 3's estimate is 1.6-fold (0.20 log units) below it; low and high end bracket the measured number.
By their numbers in this assay, from the lowest: compounds 1, 2 and 3 (each within the scatter of the next).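

Going by these compounds alone, the first direct reading at this position comes from the step in this assay where the phenyl group on the amine nitrogen in a ring gives way to 3-phenylprop-2-en-1-yl, which shows a 1.1-fold higher number from compound 2 to compound 3 (0.05 log units; within the scatter) and so stays within the usual scatter. The entering group carries 9 heavy atoms against 6 for the group that leaves, and it adds 1 double bond outside aromatic rings, yet this larger substituent does not separate compound 3 from compound 2 in this assay. Nothing measured here accounts for this outcome, and no separate observation bears on it.

What the compounds shown leave open is whether any group on this nitrogen would give a step beyond the scatter, such as a 3-phenylpropyl group, which would keep the carbon count and lose the double bond, or a carboxylic acid carried on a short chain. Also open, going by these compounds, is whether a plain methyl group, or a hydrogen on that nitrogen with no carbon substituent at all, would read level with compound 2 in this assay or apart from it.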